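Swapping an Ester for a Methoxymethyl Ether on the Core

This account rests on a few compounds, and the source may have more. Where it says the series, first, only, none or still open, it means among the compounds named here.

Compound 1 `COc1ccc(C2=C(c3cc(OC)c(OC)c(OC)c3)C(=O)CC2O[SiH2]C(C)(C)C)cc1OC`: > 100 ug/mL
Compound 2 `COc1ccc(C2=C(c3cc(OC)c(OC)c(OC)c3)C(=O)C(O[SiH2]C(C)(C)C)C2)cc1OC(C)C`: > 100 ug/mL
Compound 3 `COC(=O)c1cc(C2=C(c3cc(OC)c(OC)c(OC)c3)C(=O)CC2O[SiH2]C(C)(C)C)ccc1OC`: > 100 ug/mL

In an ADME assay on HEK293 cells (Homo sapiens) for cytotoxicity, read by MTT assay, with a stated time of 72 h (a higher number here means a weaker inhibitor, a lower number a stronger inhibitor), compound 1 gives only a limit, > 100 ug/mL. Compound 2 likewise gives a limit, > 100 ug/mL. Compound 3 also gives a limit, > 100 ug/mL, so it stands at the edge of the measurement rather than at a number. For the measured compounds named here, the one measured step that reaches it, a step that the two limits leave unreadable from compound 1 to compound 3, has no readable size because the limit of > 100 ug/mL in this assay, at which 3 of the 3 values shown sit, holds both of its ends.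

Compound 4 `COCOc1cc(C2=C(c3cc(OC)c(OC)c(OC)c3)C(=O)CC2O[SiH2]C(C)(C)C)ccc1OC` differs from compound 3 by methoxymethoxy in place of methoxycarbonyl on an aromatic carbon. Going by the values given here, no measured step bears on this change. With every value shown sitting at the limit, compound 4 is expected to give 150 ug/mL in this assay, between 60 ug/mL and 400 ug/mL. The step that the limit leaves unreadable from compound 3 to compound 4 is therefore estimated to stay within the scatter, with no clear direction.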

Compound 4, half-maximal inhibitory concentration: > 100 ug/mL
Compound 4: no number, only a limit; the forecaster's own chance of this, stated with the estimate: 80%; the middle value does not contradict the limit.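

The steps from compound 3 and from compound 1 to compound 4 cannot be read, because both ends of each step sit at the same limit: the limit of > 100 ug/mL in this assay, at which 4 of the 4 values shown sit. The compounds shown leave open whether any change to the shared core would give an actual number in this assay.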